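The source may report more compounds than this note shows. Statements on the series, on what has been measured and on what is new or still open speak of the compounds shown alone.

Working notes on the amide series sharing the bicyclic acid core. Compound 1 `CCCCNC(=O)C1C(C(=O)O)[C@@H]2CC[C@H]1O2` in an ADME assay on DU-145 cells (Homo sapiens) for cytotoxicity, read by MTT assay, with a stated time of 72 h (a higher number here means a weaker inhibitor of growth, a lower number a stronger inhibitor of growth), gives 10000 nM. Compound 2 `CCc1ccccc1NC(=O)C1C(C(=O)O)[C@@H]2CC[C@H]1O2` gives 10000 nM in this assay, and compound 3 `Cn1ccc2cc(CNC(=O)C3C(C(=O)O)[C@@H]4CC[C@H]3O4)ccc21` gives 10000 nM; compound 1 thus stands level with both at the digits recorded, within the scatter, with no ordering among the three. Compound 4 `CCCCCCCCNC(=O)C1C(C(=O)O)[C@@H]2CC[C@H]1O2` is not yet measured. Relative to compound 1 the change is butyl in place of hydrogen on a saturated chain carbon, four bonds along the chain from an amide-type nitrogen. Going by the values given here, with no measured pair of this kind to go on, and with the three recorded amides all flat, no step beyond the scatter is expected in this assay, in either direction, for compound 4; the expected step is no change at the digits printed from compound 1 to compound 4 (within the scatter). For compound 4 the estimate in this assay is 10000 nM, within 5000 nM to 20000 nM.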

Compound 4, concentration for 50% growth inhibition: 10000 nM
Estimate against measurement, compound 4: no gap at the digits printed; the range from low to high includes it.
By their numbers in this assay, from the lowest: compounds 1, 2, 3 and 4 (each within the scatter of the next).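

This position now has its first single-change pair: the step reads no change at the digits printed from compound 1 to compound 4 (within the scatter) in this assay for butyl in place of hydrogen on a saturated chain carbon, four bonds along the chain from an amide-type nitrogen. Chain extension at this place therefore leaves the read-out unmoved for this one pair, which the three earlier amides could not show. No measured evidence bears on the reason for this result. From the compounds shown here alone, whether an amine or a hydroxyl at the chain end, or a still longer chain, would shift the value remains open. Also open, going by these compounds, is whether any amide group on the shared core departs from this level.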